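The compounds below may be only part of what the source reports. "The series", "measured", "known", "first", "only" and "open" are said of these compounds alone.

Measured so far:
compound 1 `Cc1n[nH]c2nc(-c3ccc(NS(=O)(=O)c4cc(Cl)ccc4F)cc3)nc(OCC(CO)CO)c12` — 2 nM
compound 2 `Cc1n[nH]c2nc(-c3ccc(NS(=O)(=O)c4cc(Cl)ccc4F)cc3)nc(OC3CCC(=O)CC3)c12` — 18 nM

Both numbers come from an assay for inhibition of serine/threonine-protein kinase Sgk1 (Homo sapiens), with stated times of 30 min and 60 min, in the presence of a further agent that is not named here; a lower number here means a stronger inhibitor, a higher number a weaker inhibitor. Compound 2 holds the highest of the two numbers; its nearest neighbour is compound 1, and the step of a 9.0-fold higher number from compound 1 to compound 2 (0.95 log units; beyond the scatter) separates them. That step is the only one measured at this position of the shared core, and it shows that exchange of the group on the ring oxygen moves the number by a modest amount.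

Compound 3 `Cc1n[nH]c2nc(-c3ccc(NS(=O)(=O)c4cc(Cl)ccc4F)cc3)nc(OC3CC(C)(C)N(C)C(C)(C)C3)c12` is not yet measured. It differs from compound 2 by 1,2,2,6,6-pentamethylpiperidin-4-yl in place of 4-oxocyclohexyl on an oxygen on an aromatic ring. For the measured compounds named here, no measured step covers this particular exchange; the one step that bears on the position, a 9.0-fold higher number from compound 1 to compound 2 (0.95 log units; beyond the scatter), only shows that the site tolerates change with a modest shift. For compound 3 a step of a 1.2-fold lower number from compound 2 to compound 3 (0.08 log units; within the scatter) in this assay is therefore expected, no larger than the scatter in either direction. The estimate for compound 3 is 15 nM, with a range from 4 nM to 60 nM.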

Compound 3, half-maximal inhibitory concentration: 3 nM
Compound 3: the middle estimate sits 5.0-fold (0.70 log units) above what was measured, and the stated range ends above it.
By their numbers in this assay, from the lowest: compounds 1 and 3 (each within the scatter of the next); then compound 2.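

In this assay the step of a 6.0-fold lower number from compound 2 to compound 3 (0.78 log units; beyond the scatter) lies beyond the scatter, so the 4-oxocyclohexyl group is not the limit for a ring on this oxygen: 1,2,2,6,6-pentamethylpiperidin-4-yl gives a lower number. With 11 heavy atoms against 7, the entering group also shows that, between these two groups, more heavy atoms do not go with a higher number. The step of a 1.5-fold higher number from compound 1 to compound 3 (0.18 log units; within the scatter) lies within the scatter, so 1,2,2,6,6-pentamethylpiperidin-4-yl and the open 3-hydroxy-2-(hydroxymethyl)propyl chain cannot be told apart in this assay.

No supporting measurement is available to explain these differences.

The compounds shown leave open whether the ring nitrogen, its methyl groups or the loss of the carbonyl accounts for the step from the 4-oxocyclohexyl group. A plain cyclohexyl or an unmethylated piperidin-4-yl group on the same oxygen would bear on this.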